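A few compounds are considered here, and "the series" means these few. Any claim that something is new, unique, unknown or untested is made for them only; others in the source may bear on it.

Compound 1 `O=C(CBr)Nc1ccc(C(=O)/C=C/c2ccc(Cl)cc2)cc1`: 52%
Compound 2 `O=C(CBr)Nc1ccc(C(=O)/C=C/c2ccco2)cc1`: 37%

Both numbers come from a functional assay on the whole organism (strain albino) for inhibition, with Rattus norvegicus as the target, read by paw edema, with stated times of 30 min and 2 h, at a dose of 100 mg/kg by the oral route; on this read-out higher numbers stand for more inhibition at the one dose given (going by the name of the read-out) and lower numbers for less inhibition. Going by the values given here, compound 2 stands lowest of the two, with compound 1 the only neighbour. Among the compounds with values here, the single measured step, a number 15 percentage points lower from compound 1 to compound 2 (beyond the scatter), changes the group on the double-bonded chain carbon and says nothing about the amide side chain.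

Compound 3 `CC(Br)C(=O)Nc1ccc(C(=O)/C=C/c2ccco2)cc1` differs from compound 2 only on that side chain: methyl in place of hydrogen on a saturated chain carbon bound to a bromine atom and a carbonyl carbon. Within the data shown here, no measured step touches this part of the molecule, so there is no basis for expecting a move beyond the scatter in either direction. Because compound 2 gives 37% in this assay, compound 3 is expected at 37%, with a range from 22% to 52%. The expected step of no change at the digits printed from compound 2 to compound 3 (within the scatter) is essentially none, with the uncertainty of a single-dose percentage reading.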

Compound 3, a percentage reported as inhibition, in the whole organism at one dose (the size of the read-out at that dose, not a potency): 37%
For compound 3 middle estimate and measured number coincide at the digits printed, and the stated range covers the measured number.
By their numbers in this assay, from the lowest: compounds 2 and 3 (each within the scatter of the next); then compound 1.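

In this assay, methyl in place of hydrogen on the saturated chain carbon bound to a bromine atom and a carbonyl carbon gives no change at the digits printed from compound 2 to compound 3 (within the scatter). Going by these compounds alone, this is the first measured step on the amide side chain: with furan-2-yl in the molecule, the change from bromomethyl to 1-bromoethyl leaves the read-out within the scatter, whereas the step on the other side of the carbonyl, a number 15 percentage points lower from compound 1 to compound 2 (beyond the scatter), lies beyond it. No measurement available here bears on the reason for this outcome.

On these data alone, whether the same methyl gives the same result with 4-chlorophenyl in place of furan-2-yl remains open, as the side-chain reading rests on a single pair. Also open, as far as these compounds go, is how the read-out responds to an amine, a chlorine atom or a longer chain on this side chain.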